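Aryl Ketone Variation on a Shared Boron-Containing Core

A few compounds are considered here, and "the series" means these few. Any claim that something is new, unique, unknown or untested is made for them only; others in the source may bear on it.

Measured compounds:
compound 1 `O=C(/C=C/c1ccc2c(c1)B(O)OC2)c1ccccc1` gives 3400 nM
compound 2 `O=C(/C=C/c1ccc2c(c1)B(O)OC2)c1ccc(Br)cc1` gives 4500 nM
compound 3 `O=C(/C=C/c1ccc2c(c1)B(O)OC2)c1ccccc1F` gives 3700 nM

Three compounds share the same core and differ only in the aryl group on the carbonyl carbon. In a functional assay on SK-OV-3 cells (Homo sapiens) for cytotoxicity, read by MTT assay, with a stated time of 48 h (a lower number here means a stronger inhibitor, a higher number a weaker inhibitor), compound 1 gives 3400 nM, compound 2 gives 4500 nM and compound 3 gives 3700 nM. Compound 3 stands second highest of the three numbers, nearest to compound 1 and furthest from compound 2, yet every gap between them lies within the scatter: a 1.1-fold higher number from compound 1 to compound 3 (0.04 log units; within the scatter), a 1.3-fold higher number from compound 1 to compound 2 (0.12 log units; within the scatter) and a 1.2-fold lower number from compound 2 to compound 3 (0.09 log units; within the scatter).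

Compound 4 `Cc1cccc(C(=O)/C=C/c2ccc3c(c2)B(O)OC3)c1` has not yet been measured. It differs from compound 3 in one place: 3-methylphenyl in place of 2-fluorophenyl on a carbonyl carbon. Within the data shown here, the steps that bear on this change are the ones already seen on the same carbonyl carbon, from compound 1 to compound 3 and from compound 2 to compound 3, both within the scatter, so no step beyond the scatter is expected in this assay. Compound 4 is therefore estimated at 3700 nM, with a range from 1800 nM to 7500 nM, which means a step of no change at the digits printed from compound 3 to compound 4 (within the scatter) that is expected to stay within the scatter.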

Compound 4, half-maximal inhibitory concentration: 2900 nM
Beside the measured number, compound 4's estimate is 1.3-fold (0.11 log units) above it, within the range that was stated.
By their numbers in this assay, from the lowest: compounds 4, 1, 3 and 2 (each within the scatter of the next).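

In this assay, among these compounds, methyl is the first carbon-only substituent on the phenyl ring at this carbonyl carbon, and adding it gives a 1.2-fold lower number from compound 1 to compound 4 (0.07 log units; within the scatter). The exchanges of the substituted aryl groups for 3-methylphenyl also stay within the scatter, with a 1.3-fold lower number from compound 3 to compound 4 (0.11 log units; within the scatter) and a 1.6-fold lower number from compound 2 to compound 4 (0.19 log units; within the scatter), so bromo, fluoro and methyl substituents have now all been accommodated here without a step beyond it. Nothing in the available information accounts for these small differences.

On these data alone, it remains open whether an amine, a carboxylic acid or a longer alkyl chain on this phenyl ring would produce a step beyond the scatter. The compounds shown also leave open how one substituent would behave at different places on the ring, since each substituted compound carries a different group.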